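The compounds below may be only part of what the source reports. "The series", "measured", "known", "first", "only" and "open" are said of these compounds alone.

Measured compounds:
compound 1 `O=C(NC1CCN(c2ncnc3[nH]ncc23)CC1)c1ccc(Br)cc1`: 16400 nM
compound 2 `O=C(NC1CCN(c2ncnc3[nH]ncc23)CC1)c1ccc(C(F)(F)F)cc1`: 5740 nM
compound 3 `O=C(Nc1ccc(Br)cc1)NC1CCN(c2ncnc3[nH]ncc23)CC1`: 4030 nM

All three were tested in an assay on isolated protein for inhibition of serine/threonine-protein kinase PAK 1 (Homo sapiens), read by ADP-Glo, with a stated time of 40 min; on this read-out lower numbers stand for stronger inhibition and higher numbers for weaker inhibition. Compound 3 gives the lowest of the three numbers, but compound 2 lies within the scatter of it, so the two cannot be ranked. Compound 1 differs from compound 3 in the core: (4-bromophenyl)amino in place of 4-bromophenyl on a carbonyl carbon. That step went a 4.1-fold lower number from compound 1 to compound 3 (0.61 log units; beyond the scatter). Compound 1 and compound 2 differ by trifluoromethyl in place of bromo on an aromatic carbon, and that step went a 2.9-fold lower number from compound 1 to compound 2 (0.46 log units; beyond the scatter).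

Compound 4 `O=C(Nc1ccc(C(F)(F)F)cc1)NC1CCN(c2ncnc3[nH]ncc23)CC1` has not been measured. It differs from compound 3 by trifluoromethyl in place of bromo on an aromatic carbon. The place is described in the same words as for the change from compound 1 to compound 2, so this is the same change, now made on the core of compound 3. It has been seen only once, and that single step lay beyond the scatter. Among the measured compounds shown here, a step of a 2.5-fold lower number from compound 3 to compound 4 (0.40 log units; beyond the scatter) is expected, of similar size to the earlier one, because a 2.9-fold lower number from compound 1 to compound 2 (0.46 log units; beyond the scatter) is the only guide available. Compound 4 is therefore estimated at 1600 nM, with a range from 600 nM to 4500 nM to allow for a single-step basis.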

Compound 4, half-maximal inhibitory concentration: 7150 nM
The estimate for compound 4 lay 4.5-fold (0.65 log units) below the measured number, outside the stated range (above it).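

In this assay, putting trifluoromethyl in place of bromo on the core of compound 3 gave a 1.8-fold higher number from compound 3 to compound 4 (0.25 log units; within the scatter), so on this core the change cannot be told apart from repeat-to-repeat noise. The gain seen on the core of compound 1 therefore did not carry over to the core of compound 3, and the two results differ by more than measurement noise would explain: the same change on two cores in this assay, a 2.9-fold lower number (0.46 log units; beyond the scatter) from compound 1 to compound 2 and a 1.8-fold higher number (0.25 log units; within the scatter) from compound 3 to compound 4, 5.1-fold (0.70 log units) apart, beyond the scatter of two such steps This shows that, in this series, the effect of this change depends on the core it is made on, but it rests on just two pairs of compounds, so it does not show why the cores differ, nor that the change truly reverses direction on the second core.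

The compounds shown leave open whether other groups in the same place, such as a nitrile or a methoxy group, would also behave differently on the two cores. They also leave open what an amine or a carboxylic acid there would do on either core.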